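This account rests on a few compounds, and the source may have more. Where it says the series, first, only, none or still open, it means among the compounds named here.

Series notes. Compound 1 `CCCCCCCc1ccc(-c2c(C)[nH]c(=O)n2C)cc1`, compound 2 `CCCCCCCCCCCOc1ccc(-c2c(C)[nH]c(=O)n2C)cc1` and compound 3 `CCCCCCCCCCCCCCc1ccc(-c2c(C)[nH]c(=O)n2C)cc1` have been measured in a functional assay on brain (Rattus norvegicus, strain Wistar) for inhibition; on this read-out lower numbers stand for stronger inhibition and higher numbers for weaker inhibition; compound 4 `CCCCCCCCCCCCCCCCCCOc1ccc(-c2c(C)[nH]c(=O)n2C)cc1` has not. In this assay compound 1 gives 8400 nM and compound 2 gives 9700 nM, two values within the scatter of each other. Compound 3 gives 43800 nM in this assay. The difference between the cores of compound 1 and compound 2 is not broken down here. The change from compound 1 to compound 3 is heptyl in place of hydrogen on a saturated chain carbon, seven bonds along the chain from an aromatic carbon, and it produced a 5.2-fold higher number from compound 1 to compound 3 (0.72 log units; beyond the scatter). The change from compound 2 to compound 4 is heptyl in place of hydrogen on a saturated chain carbon, ten or more bonds along the chain from an oxygen on an aromatic ring; it is the same kind of change, placed further out along the chain. A step of similar size, a 4.6-fold higher number from compound 2 to compound 4 (0.67 log units; beyond the scatter), is expected because the earlier change gave a 5.2-fold higher number from compound 1 to compound 3 (0.72 log units; beyond the scatter). Compound 4 is therefore estimated at 45000 nM in this assay, within a range from 15000 nM to 150000 nM.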

Compound 4, half-maximal inhibitory concentration: > 100000 nM
Compound 4 gave a limit, no number (the forecaster's own chance of this, stated with the estimate: 15%); middle value at least 2.2-fold (0.34 log units) from the limit.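

In this assay compound 4 gives > 100000 nM, which is a limit of the assay and not a number. Heptyl in place of hydrogen on a saturated chain carbon gives an at least 10-fold higher number from compound 2 to compound 4 (1.01 log units; beyond the scatter), the same direction as on the core of compound 1: the same change on two cores in this assay, a 5.2-fold higher number (0.72 log units; beyond the scatter) from compound 1 to compound 3 and an at least 10-fold higher number (1.01 log units; beyond the scatter) from compound 2 to compound 4; the limit leaves it open whether they differ

The direction therefore carries over between these two cores, but the size of the step on the core of compound 2 stays unfixed, and nothing here shows whether the two steps match.

Still open, from the compounds shown here alone, is where, among chain lengths between those of compound 2 and compound 4, the number begins to rise. Also open, going by these compounds, is how a chain bearing an amine or a carboxylic acid would read in this assay.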